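The source may hold more compounds than are shown below. What is called first, only, known or untested is meant among the compounds shown, and "the series" means these compounds.

In an ADME assay on J774 cells (Mus musculus) for antiproliferative activity, with a stated time of 72 h (a lower number here means that less compound is needed, a higher number that more compound is needed for the effect), compound 1 (`CCc1c(C)[nH]c2cc(OCCCOC(=O)C(CC)C(C)=O)c(Cl)cc2c1=O`) is recorded as "not determined" (no result reported), so it offers no number for comparison. Compound 2 (`CCCCc1cc2c(=O)c(-c3cccnc3)c(C)[nH]c2cc1OCCOc1ccccc1`) gives 23000 nM. Among the measured compounds shown here, compound 3 (`CCCCc1cc2c(=O)c(-c3ccc(C(F)(F)F)cc3)c(C)[nH]c2cc1OCCOc1ccccc1`) gives 20000 nM, and this value lies within the scatter of the one for compound 2. For the measured compounds named here, the only measured step is a 1.2-fold lower number from compound 2 to compound 3 (0.06 log units; within the scatter), in which 4-(trifluoromethyl)phenyl takes the place of pyridin-3-yl on an aromatic carbon.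

Compound 4 (`CCCCc1cc2c(=O)c(-c3ccc(C(F)(F)F)cc3C)c(C)[nH]c2cc1OCCOc1ccccc1`) differs from compound 3 by a single change: methyl in place of hydrogen on an aromatic carbon. Methyl replaces hydrogen on an aromatic carbon, ortho to a large group and meta to a trifluoromethyl group, turning 4-(trifluoromethyl)phenyl into 2-methyl-4-(trifluoromethyl)phenyl. Going by the values given here, no measured step tests the addition of a methyl, so the evidence is indirect. The nearest guide is the exchange between compound 2 and compound 3, which involves the group that now changes again and stays within the scatter. A step beyond the scatter in this assay is therefore not expected, and the data suggest no direction. The expected step is a 1.1-fold lower number from compound 3 to compound 4 (0.05 log units; within the scatter). Compound 4 is estimated to give 18000 nM, with an expected range from 7000 nM to 45000 nM.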

Compound 4, half-maximal effective concentration: 20000 nM
Compound 4: middle estimate off by 1.1-fold (0.05 log units), on the low side; the measured number falls inside the stated range.
By their numbers in this assay, from the lowest: compounds 3, 4 and 2 (each within the scatter of the next).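

In this assay, among the compounds shown here, the methyl step is the first test of this aromatic carbon, ortho to a large group and meta to a trifluoromethyl group, and it reads no change at the digits printed from compound 3 to compound 4 (within the scatter) here, so the read-out does not separate methyl from hydrogen at this place. The wider exchange reads a 1.2-fold lower number from compound 2 to compound 4 (0.06 log units; within the scatter) in the same assay, which means that pyridin-3-yl, 4-(trifluoromethyl)phenyl and 2-methyl-4-(trifluoromethyl)phenyl on the shared core all give numbers within the scatter of one another, and adding the methyl does not open a gap that the earlier exchange lacked. No measurement is available that would account for this absence of a step.

The compounds shown leave open whether something other than methyl on this same carbon, such as a methoxy group, an ethyl group or an amine, would carry the number beyond the scatter, and whether a methyl would read the same on the pyridin-3-yl ring. They also leave open whether a carboxylic acid in place of the trifluoromethyl group would change the picture.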